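The compounds below may be only part of what the source reports. "The series", "measured", "known", "first", "only" and "open" are said of these compounds alone.

Working notes on a small series of diiodinated salicyl hydrazones and hydrazides. For the measured compounds named here, the series so far holds compound 1 `O=C(N/N=C/c1cc(I)cc(I)c1O)c1ccccc1`, compound 2 `O=C(N/N=C/c1cc(I)c(O)c(I)c1)c1ccc(C(F)(F)F)cc1` and compound 3 `COc1ccc(C(=O)NNC(=O)c2cc(I)cc(I)c2O)cc1`, all read in a functional assay on HepG2 cells (Homo sapiens) for cytotoxicity, with a stated time of 24 h; a higher number here means a weaker inhibitor, a lower number a stronger inhibitor. For compound 1 the assay reports only a limit, > 50000 nM, not a number; this is the case noted as the limit of > 50000 nM in this assay, at which 1 of the 3 values shown sits. Compound 2 gives 57400 nM. Compound 3 gives 132000 nM, the higher of the two numbers recorded, and the gap between compound 2 and compound 3 lies beyond the usual scatter of this assay. Every value in the series sits at the weak end of the measurable window.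

The next compound, compound 4 `O=C(NNC(=O)c1cc(I)cc(I)c1O)c1ccc(I)cc1`, differs from compound 3 in one place: iodo in place of methoxy on an aromatic carbon. Going by the values given here, no step between measured compounds involves that kind of change, so there is nothing to anchor a direction. Given that all three recorded values cluster in the same weak region, no step beyond the scatter is expected in this assay, and the expected step is a 1.3-fold lower number from compound 3 to compound 4 (0.12 log units; within the scatter). Compound 4 is therefore estimated at 100000 nM, with a range from 40000 nM to 250000 nM, and a real chance that the assay returns only a limit.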

Compound 4, half-maximal inhibitory concentration: 25100 nM
Beside the measured number, compound 4's estimate is 4.0-fold (0.60 log units) above it; measured number below the stated range.
By their numbers in this assay, from the lowest: compound 4; then compound 2; then compound 3.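

In this assay, iodo in place of methoxy on an aromatic carbon of the six-membered aromatic ring of carbon only, para to a large group, gives a 5.3-fold lower number from compound 3 to compound 4 (0.72 log units; beyond the scatter), so the group at this position can move the number in the hydrazide compounds. For the compounds shown here, the earlier compounds offered no step in one place, and this pair is the first reading of a single change; it also shows that the series does not have to stay in the weak region held by the first three compounds. The pair gives a direction for this one exchange only, and nothing recorded bears on the cause of the step.

Going by these compounds, a single pair cannot separate the loss of methoxy from the gain of iodo, and whether the same exchange would move the number in the hydrazones, compound 1 and compound 2, stays open. Also open, on these data alone, is what an amine, a carboxylic acid or a chlorine atom on the same aromatic carbon would do to the number, and whether any such group would follow the direction set by iodo.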